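Swapping a methoxyphenyl for naphthyl on the pyrazoline core

This account rests on a few compounds, and the source may have more. Where it says the series, first, only, none or still open, it means among the compounds named here.

Measured compounds:
- compound 1, `COc1ccc(C2CC(c3ccccc3)=NN2C2=NC(=O)/C(=C3\C(=O)Nc4ccccc43)S2)cc1`, in a functional assay on cells (Cancer cell lines, Homo sapiens) for cytotoxicity, read by sulforhodamine B assay, with a stated time of 48 h; a higher number here means a weaker inhibitor of growth, a lower number a stronger inhibitor of growth: 2020 nM
- compound 2, `COc1ccc(C2=NN(C3=NC(=O)/C(=C4\C(=O)Nc5ccccc54)S3)C(c3ccc(OC)cc3)C2)cc1`: 81500 nM

Compound 2 gives the highest of the two numbers in this assay, which makes it the weaker of the pair. Its nearest neighbour is compound 1, and the step of a 40-fold higher number from compound 1 to compound 2 (1.61 log units; beyond the scatter) is large. Among the compounds with values here, the single change in that step is a methoxy in place of hydrogen on an aromatic carbon, so the unsubstituted phenyl gave the much lower number.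

Compound 3, `COc1ccc(C2CC(c3ccc4ccccc4c3)=NN2C2=NC(=O)/C(=C3\C(=O)Nc4ccccc43)S2)cc1`, is not yet measured. It differs from compound 2 by naphthalen-2-yl in place of 4-methoxyphenyl on a carbon with a double bond to nitrogen. Within the data shown here, the only step that bears on this position is the one from compound 1 to compound 2, which shows that removing the methoxy group from this ring lowers the number strongly. Compound 3 also loses that methoxy group, but carries a second aromatic ring instead, for which no comparison exists. The step of a 14-fold lower number from compound 2 to compound 3 (1.13 log units; beyond the scatter) is therefore expected to be downward and clearly beyond the scatter, though probably not all the way back to compound 1. Compound 3 is estimated at 6000 nM, within a range from 1000 nM to 40000 nM.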

Compound 3, concentration for 50% growth inhibition: 5960 nM
The estimate for compound 3 lay 1.0-fold (0.00 log units) above the measured number, and the stated range covers the measured number.
By their numbers in this assay, from the lowest: compound 1; then compound 3; then compound 2.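

In this assay, naphthalen-2-yl in place of 4-methoxyphenyl gives a 14-fold lower number from compound 2 to compound 3 (1.14 log units; beyond the scatter), so the high number of compound 2 does not simply follow from the size of the group here: the naphthalen-2-yl group has more heavy atoms than the group it replaces, yet it gives the lower number. Set against the phenyl group, the second aromatic ring has a real but much smaller cost, with a 3.0-fold higher number from compound 1 to compound 3 (0.47 log units; beyond the scatter) compared with a 40-fold higher number from compound 1 to compound 2 (1.61 log units; beyond the scatter), so this position tolerates the extra ring far better than the methoxy group, and the plain phenyl of compound 1 still gives the lowest number of the three. No measurement is available to explain why these groups rank in this order.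

On these data alone, with only these three groups, all carbon aromatic rings with or without a methoxy group, it remains open whether the high number of compound 2 comes from the oxygen of the methoxy group or would also appear with another substituent on the ring, such as a hydroxy group, a chlorine atom or an amine. It is equally unclear whether a ring containing nitrogen, such as pyridine, or a non-aromatic group such as cyclohexyl would be tolerated at this carbon.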